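The source may hold more compounds than are shown below. What is called first, only, known or untested is meant among the compounds shown, and "the series" means these compounds.

Of the compounds shown here, three have been tested so far in an assay for inhibition of Nicotinamide phosphoribosyltransferase (Homo sapiens), read by mass spectrometry, with stated times of 15 min and 30 min; a higher number here means a weaker inhibitor, a lower number a stronger inhibitor. Compound 2, `O=C(NCc1ccc(S(=O)(=O)c2ccccc2)cc1)c1cc2ccncc2s1`, gives 7 nM. Compound 3, `O=C(NCc1ccc(S(=O)(=O)c2cccc(C(F)(F)F)c2)cc1)c1cc2ccncc2o1`, gives 5 nM, which sits within the usual scatter of the number for compound 2, so the two cannot be ranked against each other. Compound 1, `Cn1c(C(=O)NCc2ccc(S(=O)(=O)c3ccccc3)cc2)cc2cnccc21`, gives only a limit of the assay, > 10000 nM, and no number. Of the two numbers that were read, compound 2 holds the higher one, with compound 3 close to it.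

The next compound, compound 4, is `O=C(NCc1ccc(S(=O)(=O)c2ccccc2)cc1)c1c[nH]c2ccncc12`. It differs from compound 2 in one place: a group of 9 heavy atoms (7 carbon, 2 nitrogen; one five-membered aromatic ring with 1 hetero atom, one six-membered aromatic ring with 1 hetero atom) in place of a group of 9 heavy atoms (7 carbon, 1 nitrogen, 1 sulfur; one five-membered aromatic ring with 1 hetero atom, one six-membered aromatic ring with 1 hetero atom), on a carbonyl carbon. Going by the values given here, no pair of measured compounds differs by exactly this change, so no measured step shows how large its effect is. The limit seen for compound 1 shows that the related group in this position can cost a great deal of inhibition, but compound 1 also carries a different ring attachment and a methylated nitrogen, so it is not a clean guide. The step from compound 2 to compound 4 is expected to weaken inhibition by a modest amount, a 7.1-fold higher number from compound 2 to compound 4 (0.85 log units; beyond the scatter), beyond the scatter. Compound 4 is therefore estimated to give about 50 nM, with a likely range from 10 nM to 500 nM.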

Compound 4, half-maximal inhibitory concentration: 1900 nM
Compound 4: middle estimate off by 38-fold (1.58 log units), on the low side; measured number outside the range, above it.
By their numbers in this assay, from the lowest: compounds 3 and 2 (each within the scatter of the next); then compound 4. At a limit, above all of these: compound 1.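

In this assay, this change on the carbonyl carbon now has a measured size: a 270-fold higher number from compound 2 to compound 4 (2.43 log units; beyond the scatter). Two groups of equal heavy-atom count, each with one five-membered and one six-membered aromatic ring, are therefore far from interchangeable here, even though the change swaps a sulfur for a nitrogen and adds a hydrogen-bond donor without altering the ring types. Compound 4 still gives a readable number rather than reaching the limit of the assay: the limit of > 10000 nM in this assay, at which 1 of the 4 values shown sits.

The compounds shown do not separate the loss of the sulfur from the gain of the hydrogen-bond donor, so it remains open which part of the change carries the step. On these data alone, it also remains open how compound 4 or compound 2 would respond to a chlorine atom on the five-membered ring.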